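A few compounds are considered here, and "the series" means these few. Any claim that something is new, unique, unknown or untested is made for them only; others in the source may bear on it.

Compound 1 `CCCCCCCCNC(=O)Oc1ccc(Cl)cc1C(=O)Nc1cccc(Cl)c1` and compound 2 `CCCCCCCCCCNC(=O)Oc1ccc(Cl)cc1C(=O)Nc1cccc(Cl)c1` share one core and differ only in the chain that sits on the carbamate nitrogen. In an ADME assay for metabolic stability, read by HPLC, at pH 7.4 (on this read-out higher numbers stand for a longer-lived compound and lower numbers for a shorter-lived compound), compound 1 gives 43 h, and compound 2 gives 43 h. The change between them is ethyl in place of hydrogen on a saturated chain carbon, eight bonds along the chain from an amide-type nitrogen, and the step it made, no change at the digits printed from compound 1 to compound 2 (within the scatter), lies within the scatter of the measurement.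

Compound 3 `CCCNC(=O)Oc1ccc(Cl)cc1C(=O)Nc1ccc(Cl)cc1` is built on a different core; how its core differs from that of compound 1 is not broken down here. In this assay compound 3 gives 43 h, which stands level with compound 1 and compound 2.

Compound 4 `CCCCCNC(=O)Oc1ccc(Cl)cc1C(=O)Nc1ccc(Cl)cc1` is not yet measured. It arises from compound 3 by ethyl in place of hydrogen on a saturated chain carbon, three bonds along the chain from an amide-type nitrogen. Among the measured compounds shown here, this is the same kind of change as the one from compound 1 to compound 2, but not the same: there the ethyl enters eight bonds along the chain from an amide-type nitrogen, here three bonds along the chain from an amide-type nitrogen. Because no change at the digits printed from compound 1 to compound 2 (within the scatter) stayed within the scatter, the step from compound 3 to compound 4 is expected to be about no change at the digits printed from compound 3 to compound 4 (within the scatter). Compound 4 is therefore estimated at 43 h, between 22 h and 86 h.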

Compound 4, half-life: 43 h
Compound 4: the middle estimate sits on the measured number at the digits printed; measured number inside the range.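

In this assay, ethyl in place of hydrogen on a saturated chain carbon gave no change at the digits printed from compound 3 to compound 4 (within the scatter), and the earlier step on the other core agrees with it: the same change on two cores in this assay, no change at the digits printed (within the scatter) from compound 1 to compound 2 and no change at the digits printed (within the scatter) from compound 3 to compound 4, 1.0-fold (0.00 log units) apart, within the scatter of two such steps. So in these four compounds the change carries from the core of compound 1 to the core of compound 3 with no step beyond the scatter on either, even though the ethyl enters eight bonds along the chain in one case and three bonds along it in the other. This does not show that the same holds on any other core, and two flat steps cannot show how well a change with a clear effect on the half-life would carry over.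

The compounds shown leave open what a chain longer than any of these, or a chain carrying an amine or a carboxylic acid, would do to the half-life. They also leave open whether any change to the chain on these two cores can move this read-out at all.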